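Estimating cell toxicity for a tert-butyl benzyl compound

A few compounds are considered here, and "the series" means these few. Any claim that something is new, unique, unknown or untested is made for them only; others in the source may bear on it.

Measured in a toxicity assay on NIH3T3 cells (Mus musculus) for cytotoxicity, read by resazurin assay; a higher number here means that more compound is needed for the effect, a lower number that less compound is needed
- compound 1 (`COC(=O)c1ccc(NCc2cncn2Cc2ccccc2C)cc1-c1ccccc1`) gives 10000 nM
- compound 2 (`COC(=O)c1ccc(NCc2cncn2Cc2ccc(-c3ccccc3)cc2)cc1-c1ccccc1`) gives > 1000 nM (a limit)
- compound 3 (`COC(=O)c1ccc(NCc2cncn2Cc2ccccc2OC)cc1-c1ccccc1`) gives "not determined" (no result reported)

Compound 3 stands at "not determined" (no result reported) and so offers no number to start from. Compound 4 (`COC(=O)c1ccc(NCc2cncn2Cc2cccc(C(C)(C)C)c2)cc1-c1ccccc1`) differs from it in one group (3-(tert-butyl)phenyl in place of 2-methoxyphenyl on a saturated chain carbon bound to an aromatic nitrogen) on a saturated chain carbon bound to an aromatic nitrogen. Among the measured compounds shown here, only one measured step changes this same place, a step that the limit leaves unreadable from compound 1 to compound 2, and it gives no size to carry over. Compound 2 carries the limit of > 1000 nM in this assay, at which 1 of the 3 values shown sits, and that is a limit, not a number. For the measured compounds named here, no step of known size or direction is therefore expected in this assay, and compound 1 at 10000 nM remains the only firm anchor. Compound 4 is expected near 8000 nM with an estimated range from 2000 nM to 30000 nM in a deliberately wide span.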

Compound 4, half-maximal effective concentration: > 1000 nM
Compound 4: no number, only a limit; the forecaster's own chance of this, stated with the estimate: 45%; the middle value is on the limit's open side.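

No step can be read from compound 1 or compound 2 to compound 4, because compound 2 and compound 4 both stop at one limit: the limit of > 1000 nM in this assay, at which 2 of the 4 values shown sit. From the compounds shown here alone, how far either compound lies beyond that limit in this assay stays open.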